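Aryl amide series: 3-fluorophenyl to 3-chloro-4-fluorophenyl

The compounds below may be only part of what the source reports. "The series", "measured", "known", "first", "only" and "open" are said of these compounds alone.

Among the measured compounds shown here, in a functional assay on HT-29 cells (Homo sapiens) for cytotoxicity, read by MTT assay, with a stated time of 72 h (on this read-out lower numbers stand for stronger inhibition and higher numbers for weaker inhibition), compound 3 `O=C(CN1CCN(c2nnc(Cc3ccccc3)c3ccccc23)CC1)Nc1cccc(F)c1` gives 95000 nM, the highest of the three numbers measured so far. Compound 1 `O=C(CN1CCN(c2nnc(Cc3ccccc3)c3ccccc23)CC1)Nc1ccc(F)c(C(F)(F)F)c1` gives 4590 nM and compound 2 `O=C(CN1CCN(c2nnc(Cc3ccccc3)c3ccccc23)CC1)Nc1ccc(F)c(F)c1` gives 9510 nM. The next change leads to compound 4 `O=C(CN1CCN(c2nnc(Cc3ccccc3)c3ccccc23)CC1)Nc1ccc(F)c(Cl)c1`: 3-chloro-4-fluorophenyl in place of 3-fluorophenyl on an amide-type nitrogen. In words, 3-chloro-4-fluorophenyl comes in place of 3-fluorophenyl on an amide-type nitrogen, and the shared core stays untouched.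

For the measured compounds named here, two measured steps bear most directly on this change, both ending at the 3-fluorophenyl compound: a 21-fold higher number from compound 1 to compound 3 (1.32 log units; beyond the scatter), which is large, and a 10-fold higher number from compound 2 to compound 3 (1.00 log units; beyond the scatter), which is modest. Read backwards, each shows a much lower number than that of compound 3 once the aryl group is changed. The remaining step, a 2.1-fold higher number from compound 1 to compound 2 (0.32 log units; beyond the scatter), is modest and shows how far the two lower values lie apart. Going by the values given here, three compounds are a thin basis, and no chlorine-bearing compound has been measured. Compound 4 is nevertheless expected to fall near compound 1 and compound 2 rather than near compound 3.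

The estimated step is a 14-fold lower number from compound 3 to compound 4 (1.13 log units; beyond the scatter), a large one towards a lower number. For compound 4 the expected value is 7000 nM, with an estimated range of 3000 nM to 18000 nM.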

Compound 4, half-maximal inhibitory concentration: 13300 nM
Beside the measured number, compound 4's estimate is 1.9-fold (0.28 log units) below it, and the stated range covers the measured number.
By their numbers in this assay, from the lowest: compound 1; then compounds 2 and 4 (each within the scatter of the next); then compound 3.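

In this assay, the 3-chloro-4-fluorophenyl amide shows that chloro can take the place of the groups in compound 1 and compound 2 with the number remaining far from that of the 3-fluorophenyl amide: a 7.1-fold lower number from compound 3 to compound 4 (0.85 log units; beyond the scatter). Chloro and fluoro on this aromatic carbon cannot be told apart here, with a 1.4-fold higher number from compound 2 to compound 4 (0.15 log units; within the scatter), whereas the trifluoromethyl compound stays distinct, with a 2.9-fold higher number from compound 1 to compound 4 (0.46 log units; beyond the scatter), and so compound 1 keeps the lowest number of the four. Nothing available on the compounds accounts for this order, and the values alone describe the change at this position.

Still open, from the compounds shown here alone, is how a methoxy group, a nitrile or an amine on the same aromatic carbon would compare with chloro, fluoro and trifluoromethyl in this read-out. Also open, going by these compounds, is how much of the step from the 3-fluorophenyl amide comes from chloro and how much from the added fluoro, and whether a longer chain in place of the aryl group on the amide-type nitrogen would keep the number near those of compound 2 and compound 4.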